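Fluoro-for-bromo exchange on the benzoyl of compound 3

The source may hold more compounds than are shown below. What is called first, only, known or untested is meant among the compounds shown, and "the series" means these compounds.

Among the compounds with values here, compound 3 `COc1cc(OC)c(C(=O)c2ccccc2Br)c(O)c1CN1CCCC1` gives 19% in a functional assay on THP-1 cells (Homo sapiens) for inhibition, read by ELISA, with stated times of 30 min and 24 h, tested at 1 uM (a lower number here means a weaker effect, a higher number a stronger effect of the compound at the concentration tested), which places it second highest of the three numbers measured so far. Compound 1 `COc1cc(OC)c(C(=O)c2ccccc2F)c(O)c1CN1CCCC1` gives 15% and compound 2 `COc1cc(OC)c(C(=O)c2cccc(F)c2)c(O)c1CN1CCCCC1` gives 30% in this assay. Within the data shown here, the only single-point step measured, a number 4 percentage points higher from compound 1 to compound 3 (within the scatter), lies within the scatter. Compound 4 `COc1cc(OC)c(C(=O)c2cccc(F)c2)c(O)c1CN1CCCC1` differs from compound 3 by 3-fluorophenyl in place of 2-bromophenyl on a carbonyl carbon. Among the measured compounds shown here, no measured step bears directly on this exchange; compound 2 also carries a 3-fluorophenyl but differs from compound 4 elsewhere, so its value is only a loose hint. The step expected in this assay, a number 5 percentage points higher from compound 3 to compound 4 (within the scatter), is therefore small, with no clear direction beyond the scatter. Compound 4 is estimated at 24%, range 10% to 38%.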

Compound 4, a percentage reported as activity, at one concentration (the size of the read-out at that concentration, not a potency): 34%
Compound 4: the middle estimate sits 10 percentage points below what was measured; the measured number falls inside the stated range.
By their numbers in this assay, from the lowest: compounds 1 and 3 (each within the scatter of the next); then compounds 2 and 4 (each within the scatter of the next).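

The step of a number 19 percentage points higher from compound 1 to compound 4 (beyond the scatter) comes with 3-fluorophenyl in place of 2-fluorophenyl, so in this assay the place of the fluoro on this phenyl counts, not only the halogen present. The step of a number 15 percentage points higher from compound 3 to compound 4 (beyond the scatter) likewise favours 3-fluorophenyl on the carbonyl carbon, while a number 4 percentage points higher from compound 2 to compound 4 (within the scatter) does not tell pyrrolidin-1-yl and piperidin-1-yl apart when 3-fluorophenyl is present. No evidence at hand explains these steps. Open, on these data alone, are a 3-bromophenyl, which would separate the halogen from its place on the phenyl, and a morpholine in place of pyrrolidin-1-yl.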